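Formyl to hydroxymethyl on the side chain, two cores

The source may hold more compounds than are shown below. What is called first, only, known or untested is meant among the compounds shown, and "the series" means these compounds.

Compound 1 `Cn1nc(Cc2nnc(SCCCCCCCC(=O)Nc3ccc(Cl)cc3Cl)n2CCC=O)c2ccccc2c1=O` and compound 2 `Cn1nc(Cc2nnc(SCCCCCCCC(=O)Nc3ccc(Cl)cc3Cl)n2CCCO)c2ccccc2c1=O` share one core; compound 3 `Cn1c(Cc2nn(CCC=O)c(=O)c3ccccc23)nnc1SCC(=O)Nc1ccc(Cl)cc1Cl` and compound 4 `Cn1c(Cc2nn(CCCO)c(=O)c3ccccc23)nnc1SCC(=O)Nc1ccc(Cl)cc1Cl` share another. The difference between the two cores is not broken down here. In an assay on 32D cells for inhibition of interleukin-15 (Mus musculus), read by resazurin assay, with stated times of 30 min and 2.5 days, in the presence of a further agent that is not named here (on this read-out higher numbers stand for weaker inhibition and lower numbers for stronger inhibition), compound 1 gives 2500 nM. For compound 2 the result is a limit of the assay, > 30000 nM. The change hydroxymethyl in place of formyl on a saturated chain carbon, two bonds along the chain from an aromatic nitrogen thus brings an at least 12-fold higher number from compound 1 to compound 2 (1.07 log units; beyond the scatter), and the step is bounded only by the limit of > 30000 nM in this assay, at which 1 of the 3 values shown sits. In this assay compound 3 gives 30000 nM, a higher number than compound 1 beyond the scatter. Compound 4 carries the same change, (hydroxymethyl in place of formyl on a saturated chain carbon, two bonds along the chain from an aromatic nitrogen), on the second core; the place lines of both changes read alike, so this is the same change, not merely the same kind. Compound 4 is expected to show a 2.0-fold higher number from compound 3 to compound 4 (0.30 log units; within the scatter) because an at least 12-fold higher number from compound 1 to compound 2 (1.07 log units; beyond the scatter) points that way. Compound 4 is therefore estimated at 60000 nM, between 20000 nM and 200000 nM in this assay, with a strong chance that only a limit is reported.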

Compound 4, half-maximal inhibitory concentration: > 30000 nM
Compound 4 ended at the assay's limit (the forecaster's own chance of this, stated with the estimate: 80%); the middle value lies beyond the limit too.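

In this assay compound 4 gives > 30000 nM, which is a limit of the assay and not a number. The change therefore brings a number no lower from compound 3 to compound 4 (the limit leaves the size open), and the two cores can be compared in direction only: the same change on two cores in this assay, an at least 12-fold higher number (1.07 log units; beyond the scatter) from compound 1 to compound 2 and a number no lower (the limit leaves the size open) from compound 3 to compound 4; the limit leaves it open whether they differ. The direction holds on both cores, with the hydroxymethyl compound giving no lower number than its formyl partner, but these two pairs cannot show whether the size of the change carries from one core to the other, and the top of the range limits the comparison: the limit of > 30000 nM in this assay, at which 2 of the 4 values shown sit.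

Going by these compounds, it remains open whether the formyl group is specifically required at this place on the side chain, or whether a carboxylic acid or an amine in its position would give a value inside the range of the assay. Also open, on these data alone, is how a longer chain in place of 2-formylethyl would read on each core.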